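Buffer stability and the oxygen substituent in this series

The source may report more compounds than this note shows. Statements on the series, on what has been measured and on what is new or still open speak of the compounds shown alone.

Going by the values given here, compound 2 `COC(=O)N1CCN(C(=O)c2nc(Nc3cc(C4CC4)[nH]n3)c3cc(Cl)ccc3n2)C[C@H]1C` holds the highest of the two numbers so far in a physicochemical assay, read by HPLC, in phosphate buffer, with a stated time of 2 h, at pH 7.4 (on this read-out lower numbers stand for a less stable compound and higher numbers for a more stable compound), where compound 2 gives 100%; compound 1 `C[C@@H]1CN(C(=O)c2nc(Nc3cc(C4CC4)[nH]n3)c3cc(Cl)ccc3n2)CCN1C(=O)OCc1ccccc1` is nearest, and in this assay compound 1 gives 97.7%, with the step of a number 2.3 percentage points higher from compound 1 to compound 2 (within the scatter) inside the scatter. Compound 3 `CC(OC(=O)C(C)C)OC(=O)N1CCN(C(=O)c2nc(Nc3cc(C4CC4)[nH]n3)c3cc(Cl)ccc3n2)C[C@H]1C` differs from compound 2 by 1-((isopropylcarbonyl)oxy)ethyl in place of methyl on an oxygen next to a carbonyl group. Among the compounds with values here, the only measured step bearing on this place, a number 2.3 percentage points higher from compound 1 to compound 2 (within the scatter), altered the group on the same oxygen without a shift beyond the scatter, so no step beyond the scatter is expected here either. Compound 3 is therefore expected to show a number 5 percentage points lower from compound 2 to compound 3 (within the scatter), an estimate of 95% with a range from 85% to 100%.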

Compound 3, percent of the compound remaining: 96.6%
Beside the measured number, compound 3's estimate is 1.6 percentage points below it; low and high end bracket the measured number.
By their numbers in this assay, from the lowest: compounds 3, 1 and 2 (each within the scatter of the next).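

In this assay the change to 1-((isopropylcarbonyl)oxy)ethyl on an oxygen next to a carbonyl group gives a number 3.4 percentage points lower from compound 2 to compound 3 (within the scatter) from methyl and a number 1.1 percentage points lower from compound 1 to compound 3 (within the scatter) from benzyl. Going by these compounds alone, this is the first group on this oxygen that itself carries a second carbonyl, and neither step leaves the scatter. Methyl, benzyl and 1-((isopropylcarbonyl)oxy)ethyl thus cannot be told apart at this position on this read-out, and no measurement in hand offers a reason for that.

Still open, as far as these compounds go, is whether a chain ending in an amine or a carboxylic acid on this oxygen would stay within the scatter of these three.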